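The source may hold more compounds than are shown below. What is called first, only, known or untested is meant among the compounds shown, and "the series" means these compounds.

Working notes on the series. In a functional assay on HepG2 cells (Homo sapiens) for inhibition, read by MTT assay, with a stated time of 72 h (a lower number here means a stronger inhibitor, a higher number a weaker inhibitor), compound 1 `C#CCSc1nc(Nc2cc(OC)c(OC)c(OC)c2)c2ccncc2n1` gives 14200 nM, and compound 2 `CCSc1nc(Nc2cccc(OC)c2)c2ccncc2n1` gives 10700 nM; the number for compound 2 and that for compound 1 lie within the scatter of each other, so nothing separates them. Compound 3 `C/C=C/Sc1nc(Nc2cccc(OC)c2)c2ccncc2n1` is not yet measured; it differs from compound 2 by prop-1-en-1-yl in place of ethyl on a sulfur. Going by the values given here, no step between measured compounds is available. The step from compound 2 to compound 3 is expected to be small, a 1.1-fold lower number from compound 2 to compound 3 (0.05 log units; within the scatter), not beyond the scatter in either direction. For compound 3 the estimated value in this assay is 9500 nM, with a range from 4000 nM to 25000 nM.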

Compound 3, half-maximal inhibitory concentration: 18100 nM
Estimate against measurement, compound 3: 1.9-fold (0.28 log units) below; measured number inside the range.
By their numbers in this assay, from the lowest: compounds 2, 1 and 3 (each within the scatter of the next).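

Going by these compounds alone, this is the first single-change comparison at this position: on a sulfur, prop-1-en-1-yl in place of ethyl gives in this assay a 1.7-fold higher number from compound 2 to compound 3 (0.23 log units; within the scatter). Adding a carbon and a double bond to this group therefore does not separate compound 3 from compound 2 in this assay. No measured property bears on this step.

Still open, as far as these compounds go, is whether a longer chain, a carboxylic acid or an amine in place of ethyl on a sulfur would give a step beyond the scatter.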